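Allyloxy tail on the shared core: notes toward compound 4

A few compounds are considered here, and "the series" means these few. Any claim that something is new, unique, unknown or untested is made for them only; others in the source may bear on it.

Compound 2 `O=c1c(-c2ccc(O)cc2)coc2cc(OCCCCBr)ccc12` stands highest of the three numbers in a functional assay on mitochondria (Cricetulus griseus) for inhibition of Monoamine oxidase (Homo sapiens), tested at 3 uM (on this read-out higher numbers stand for a stronger effect at the one concentration tested and lower numbers for a weaker effect), where compound 2 gives 84.7%. Compound 3 `O=c1c(-c2ccc(O)cc2)coc2cc(OCCC3OCCCO3)ccc12` comes nearest; in this assay compound 3 gives 75.3%, and the change a number 9.4 percentage points lower from compound 2 to compound 3 (within the scatter) does not leave the scatter. Compound 1 `O=c1c(-c2ccc(O)cc2)coc2cc(CC3OC(CO)C(O)C(O)C3O)ccc12` lies furthest away: in this assay compound 1 gives 0%, a gap from compound 2 that is beyond the scatter. Compound 1 differs from compound 2 in more than one place, so it marks only how low the read-out can go on this core.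

Compound 4 `C=CCOc1ccc2c(=O)c(-c3ccc(O)cc3)coc2c1` differs from compound 2 as vinyl in place of 3-bromopropyl on a saturated chain carbon bound to an oxygen on an aromatic ring. Going by the values given here, one measured step bears on the ether chain: a number 9.4 percentage points lower from compound 2 to compound 3 (within the scatter), which exchanged the group two bonds along the chain from the aromatic oxygen without moving the read-out beyond the scatter. Among the compounds with values here, the change to compound 4 is of another kind, shortening the chain and removing the bromine rather than exchanging the group at its end, and no measured pair speaks to a shortened chain. For compound 4 a step of a number 19.7 percentage points lower from compound 2 to compound 4 (beyond the scatter) is expected, a modest loss carrying wider uncertainty than the measured pair alone would suggest. Compound 4 is estimated at 65%, with a range from 35% to 90%.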

Compound 4, a percentage reported as inhibition, at one concentration (the size of the read-out at that concentration, not a potency): 89.3%
Compound 4: the middle estimate sits 24.3 percentage points below what was measured; the measured number falls inside the stated range.
By their numbers in this assay, from the lowest: compound 1; then compounds 3, 2 and 4 (each within the scatter of the next, the first and the last beyond it).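

At this position, in this assay, the step of a number 4.6 percentage points higher from compound 2 to compound 4 (within the scatter) shows that the read-out tolerates vinyl in place of 3-bromopropyl on a saturated chain carbon bound to an oxygen on an aromatic ring, a change that also reads as 4-bromobutoxy to allyloxy, so neither the bromine nor the 4-bromobutyl length is required for a read-out of this size. The step of a number 14 percentage points higher from compound 3 to compound 4 (beyond the scatter) is modest but beyond the scatter, which gives this ether position a difference that the earlier pair, within the scatter, did not show, and it goes with a group without a ring replacing one that holds a six-membered non-aromatic ring. No measurement at hand offers a reason for either step.

As far as these compounds go, whether an amine, a carboxylic acid or a longer chain without bromine on the same ether oxygen would hold the read-out at this level remains open. A percentage at one concentration also leaves open how far the potencies of the ether-tailed compounds differ, since these values say nothing about potency.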